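The source may report more compounds than this note shows. Statements on the series, on what has been measured and on what is new or still open speak of the compounds shown alone.

Measured compounds so far:
- compound 1, `Cn1nc(COc2cc(F)cc(F)c2)c2c1CCN(C(=O)NC1CCCCC1)C2`; in an assay on cells for inhibition of Pendrin (Mus musculus), read by fluorescence, with a stated time of 10 min (on this read-out higher numbers stand for weaker inhibition and lower numbers for stronger inhibition), compound 1 gives > 10000 nM, a limit of the assay.
- compound 2, `Cn1nc(COc2cc(F)cc(F)c2)c2c1CCN(S(=O)(=O)c1ccc(C(F)(F)F)cc1)C2`; in this assay compound 2 gives > 10000 nM, again a limit.

Going by the values given here, compound 2 therefore has no number of its own in this assay, only a limit; the one other value shown for the series is likewise a limit, so both sit at the limit of > 10000 nM in this assay, at which 2 of the 2 values shown sit, and no step between measured compounds can be sized.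

Compound 3, `CCN(CC)S(=O)(=O)N1CCc2c(c(COc3cc(F)cc(F)c3)nn2C)C1`, differs from compound 2 in one place: diethylamino in place of 4-(trifluoromethyl)phenyl on a sulfonyl sulfur. With both reference values at the limit, no direction can be read from the data; the step from compound 2 to compound 3 is expected to be a number no higher from compound 2 to compound 3 (the limit leaves the size open), which is to say no change beyond the scatter. Compound 3 is therefore estimated at 10000 nM, with a range from 3000 nM to 30000 nM, and most likely reported as a limit again.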

Compound 3, half-maximal inhibitory concentration: > 10000 nM
Compound 3: a limit, no number (the forecaster's own chance of this, stated with the estimate: 80%); the middle value sits exactly at the limit.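

Compound 3 gives a limit and no number, so the steps to it from compound 1 and compound 2 cannot be read: the limit of > 10000 nM in this assay, at which 3 of the 3 values shown sit.

The compounds shown leave open which group on the amine nitrogen in a ring, if any, gives a measurable value in this assay.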